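Swapping the aryl group on the chain: solubility outlook

A few compounds are considered here, and "the series" means these few. Any claim that something is new, unique, unknown or untested is made for them only; others in the source may bear on it.

Of the compounds shown here, three sharing one core have been measured in a physicochemical assay for solubility, at pH 7.8; on this read-out lower numbers stand for lower solubility and higher numbers for higher solubility. Compound 1 `O=C(CN1CCN(c2cc3c(cc2F)c(=O)c(C(=O)O)cn3C2CC2)CC1)Nc1ccc(C(=O)/C=C/c2ccccc2Cl)cc1` gives 2.12 ug/mL. Compound 2 `O=C(CN1CCN(c2cc3c(cc2F)c(=O)c(C(=O)O)cn3C2CC2)CC1)Nc1ccc(C(=O)/C=C/c2cccc(Cl)c2)cc1` gives 29.7 ug/mL. Compound 3 `COc1ccc(/C=C/C(=O)c2ccc(NC(=O)CN3CCN(c4cc5c(cc4F)c(=O)c(C(=O)O)cn5C4CC4)CC3)cc2)cc1OC` gives 0.68 ug/mL, the lowest of the three: compound 1 sits nearest to it and compound 2 furthest.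

The new compound 4 `Cc1ccc(/C=C/C(=O)c2ccc(NC(=O)CN3CCN(c4cc5c(cc4F)c(=O)c(C(=O)O)cn5C4CC4)CC3)cc2)c(C)c1` differs from compound 3 in one place: 2,4-dimethylphenyl in place of 3,4-dimethoxyphenyl on a double-bonded chain carbon bound to a double-bonded chain carbon. Among the compounds with values here, no measured pair makes exactly this change, but all three measured steps alter the same aryl group on the same chain carbon. The step from the 2-chlorophenyl to the 3-chlorophenyl gave a 14-fold higher number from compound 1 to compound 2 (1.15 log units; beyond the scatter), the step to the 3,4-dimethoxyphenyl gave a 3.1-fold lower number from compound 1 to compound 3 (0.49 log units; beyond the scatter) from compound 1 and a 44-fold lower number from compound 2 to compound 3 (1.64 log units; beyond the scatter) from compound 2. Changes at this position therefore move this assay by large amounts in either direction, and the 3,4-dimethoxyphenyl of compound 3 lies at the bottom of the range seen so far.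

Since compound 3 already stands at the lowest number, and the two other aryl groups both gave higher numbers, an upward step is expected for compound 4, estimated as a 3.7-fold higher number from compound 3 to compound 4 (0.57 log units; beyond the scatter). The estimated value for compound 4 is 2.5 ug/mL, within a range from 0.5 ug/mL to 12 ug/mL.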

Compound 4, solubility: 2.07 ug/mL
For compound 4 the middle estimate is 1.2-fold (0.08 log units) above the measured one; the range from low to high includes it.
By their numbers in this assay, from the lowest: compound 3; then compounds 4 and 1 (each within the scatter of the next); then compound 2.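

In this assay, putting the 2,4-dimethylphenyl, a group of carbon only, in place of the oxygen-bearing 3,4-dimethoxyphenyl on this chain carbon gives a 3.0-fold higher number from compound 3 to compound 4 (0.48 log units; beyond the scatter), so compound 3 stays alone at the bottom of the series. The 2-chlorophenyl and the 2,4-dimethylphenyl cannot be told apart here, with a 1.0-fold lower number from compound 1 to compound 4 (0.01 log units; within the scatter), whereas the change from the 3-chlorophenyl gives a 14-fold lower number from compound 2 to compound 4 (1.16 log units; beyond the scatter), leaving compound 2 alone at the top and showing that a second aryl group can land at the level of compound 1 rather than near compound 2. No measurement shown here explains these differences.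

On these data alone, with only four aryl groups, which differ in both their substituents and the places those substituents occupy, it remains open whether the high number of compound 2 goes with the chlorine itself or with the place it holds on the ring. A 3-methylphenyl, a 4-chlorophenyl or an unsubstituted phenyl at this chain carbon would help separate those two readings, while an aryl group carrying an amine would test a kind of substituent absent from these four compounds.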